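Dimethylamino for cyano on the pendant aryl

The compounds below may be only part of what the source reports. "The series", "measured", "known", "first", "only" and "open" are said of these compounds alone.

Working notes on the series. The shared core is carried by compound 1 `CC(C)c1cc(C(C)(C)C)cc(-c2cccc(C(F)(F)F)c2)c1CO`, compound 2 `CC(C)c1cc(C(C)(C)C)cc(-c2cccc(C#N)c2)c1CO` and compound 3 `CC(C)c1cc(C(C)(C)C)cc(-c2ccccc2-c2ccccc2)c1CO`. In a functional assay on RKE cells for antagonist activity at Vasoactive intestinal polypeptide receptor 1 (Rattus norvegicus), read by HTRF and cAMP accumulation, with stated times of 10 min and 30 min (on this read-out higher numbers stand for weaker inhibition and lower numbers for stronger inhibition), compound 2 reports only a limit, > 50000 nM. Compound 1 likewise gives only a limit, > 50000 nM. Compound 3 is measured at 3200 nM. Among the compounds with values here, the one measured step, a step that the two limits leave unreadable from compound 1 to compound 2, cannot be read due to the limit of > 50000 nM in this assay, at which 2 of the 3 values shown sit. Compound 4 `CC(C)c1cc(C(C)(C)C)cc(-c2cccc(N(C)C)c2)c1CO` differs from compound 2 by dimethylamino in place of cyano on an aromatic carbon. Within the data shown here, no measured step bears on dimethylamino, and the single step at that position is unreadable, so no direction in this assay can be drawn; the limit seen for compound 2 is the only anchor. In this assay compound 4 is expected near 50000 nM, within a range from 15000 nM to 200000 nM. The expected step of a number no higher from compound 2 to compound 4 (the limit leaves the size open) is no change beyond the scatter.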

Compound 4, half-maximal inhibitory concentration: 310 nM
Compound 4: middle estimate off by 160-fold (2.21 log units), on the high side, and the stated range ends above it.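

In this assay, dimethylamino in place of cyano gives an at least 160-fold lower number from compound 2 to compound 4 (2.20 log units; beyond the scatter), and dimethylamino in place of trifluoromethyl gives an at least 160-fold lower number from compound 1 to compound 4 (2.20 log units; beyond the scatter). This position on the pendant aromatic ring therefore tolerates a substituent that gives a measured value, and the choice of group there matters, which neither cyano nor trifluoromethyl could show. The step from compound 1 to compound 2 remains unreadable: the limit of > 50000 nM in this assay, at which 2 of the 4 values shown sit.

From the compounds shown here alone, whether a primary amine, a methylamino group or a methoxy group at this place would match compound 4 stays open. So does whether a larger amine such as pyrrolidine would be tolerated there.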